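Replacing Hydroxy with Methyl on the Aromatic Ring

The source may hold more compounds than are shown below. What is called first, only, known or untested is meant among the compounds shown, and "the series" means these compounds.

Measured in a functional assay on HUVEC cells (Homo sapiens) for cytotoxicity; a lower number here means that less compound is needed, a higher number that more compound is needed for the effect:
- compound 1 `COC1=C(C)C(=O)/C(=C(O)/C=C/c2ccc(OC)cc2)C(=O)C1(C)C` gives 2.5 ug/mL
- compound 2 `COC1=C(C)C(=O)/C(=C(O)/C=C/c2ccccc2OC)C(=O)C1(C)C` gives 1.7 ug/mL
- compound 3 `COC1=C(C)C(=O)/C(=C(O)/C=C/c2ccc(O)cc2)C(=O)C1(C)C` gives 3.8 ug/mL

Compound 3 has the highest number of the three, but only one of its gaps is clear: a 2.2-fold higher number from compound 2 to compound 3 (0.35 log units; beyond the scatter), whereas a 1.5-fold higher number from compound 1 to compound 3 (0.18 log units; within the scatter). Compound 4 `COC1=C(C)C(=O)/C(=C(O)/C=C/c2ccc(C)cc2)C(=O)C1(C)C` differs from compound 3 by having methyl in place of hydroxy on an aromatic carbon. Within the data shown here, no measured step makes this exact change. The closest is the step to compound 3 from compound 1, which carries 4-methoxyphenyl, and that step stayed within the scatter. No step beyond the scatter is therefore expected in this assay. The expected change is a 1.5-fold lower number from compound 3 to compound 4 (0.16 log units; within the scatter). Compound 4 is estimated at 2.6 ug/mL, with an expected range of 1.3 ug/mL to 5.2 ug/mL.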

Compound 4, concentration for half-maximal effect: 2.4 ug/mL
Compound 4: the middle estimate sits 1.1-fold (0.03 log units) above what was measured; the measured number falls inside the stated range.
By their numbers in this assay, from the lowest: compounds 2, 4, 1 and 3 (each within the scatter of the next, the first and the last beyond it).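

In this assay, methyl, which carries no hydrogen-bond donor or acceptor, replaces hydroxy on the aromatic carbon para to a large group, giving a 1.6-fold lower number from compound 3 to compound 4 (0.20 log units; within the scatter), so at this position the number does not depend clearly on having that hydroxy. Methyl in place of methoxy gives a 1.0-fold lower number from compound 1 to compound 4 (0.02 log units; within the scatter), and 4-methylphenyl in place of 2-methoxyphenyl gives a 1.4-fold higher number from compound 2 to compound 4 (0.15 log units; within the scatter). Nothing available explains why these swaps leave the number within the scatter. As far as these compounds go, whether an amine, a carboxylic acid or a longer chain at this position would do the same remains open.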